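The source may hold more compounds than are shown below. What is called first, only, known or untested is meant among the compounds shown, and "the series" means these compounds.

Four close relatives share one core and differ in two places. Compound 1 `C#CCNC(=O)/C(C)=C(\C)c1ccc(Br)cc1` carries bromo on the ring and a propargyl chain on the amide nitrogen. Compound 2 `C=CCNC(=O)/C(C)=C(\C)c1ccc(Br)cc1` keeps the bromo but has an allyl chain. Compound 3 `C#CCNC(=O)/C(C)=C(\C)c1ccc(C)cc1` keeps the propargyl chain but carries methyl on the ring. Compound 4 `C=CCNC(=O)/C(C)=C(\C)c1ccc(C)cc1` combines the methyl ring with the allyl chain and has not yet been measured.

In a toxicity assay on the whole organism (strain Icem-CET (SPF Caw)) for cytotoxicity, with Mus musculus as the target (a lower number here means that less compound is needed, a higher number that more compound is needed for the effect), compound 1 gives 150 mg/kg, compound 2 gives 500 mg/kg, and compound 3 gives 150 mg/kg. The swap on the ring, (methyl in place of bromo on an aromatic carbon), made no change at the digits printed from compound 1 to compound 3 (within the scatter). The chain swap, (vinyl in place of ethynyl on a saturated chain carbon bound to an amide-type nitrogen), made a 3.3-fold higher number from compound 1 to compound 2 (0.52 log units; beyond the scatter).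

The same chain swap now appears again as vinyl in place of ethynyl on a saturated chain carbon bound to an amide-type nitrogen, at the very same place. Among the compounds with values here, only one earlier example of it exists, so the expectation rests on compound 1 and compound 2 alone, which showed a 3.3-fold higher number from compound 1 to compound 2 (0.52 log units; beyond the scatter). Starting from compound 3, a step of about a 3.0-fold higher number from compound 3 to compound 4 (0.48 log units; beyond the scatter) is therefore expected in this assay. On that basis compound 4 is estimated at 450 mg/kg.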

Compound 4, dose for half-maximal effect: 150 mg/kg
Estimate against measurement, compound 4: 3.0-fold (0.48 log units) above, and the stated range ends above it.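

In this assay, putting allyl in place of propargyl gave no change at the digits printed from compound 3 to compound 4 (within the scatter), so the step seen with bromo on the ring did not carry over to the core with methyl: the same change on two cores in this assay, a 3.3-fold higher number (0.52 log units; beyond the scatter) from compound 1 to compound 2 and no change at the digits printed (within the scatter) from compound 3 to compound 4, 3.3-fold (0.52 log units) apart, beyond the scatter of two such steps. Read the other way, methyl in place of bromo gave a 3.3-fold lower number from compound 2 to compound 4 (0.52 log units; beyond the scatter) with the allyl chain, unlike its result with the propargyl chain: the same change on two cores in this assay, no change at the digits printed (within the scatter) from compound 1 to compound 3 and a 3.3-fold lower number (0.52 log units; beyond the scatter) from compound 2 to compound 4, 3.3-fold (0.52 log units) apart, beyond the scatter of two such steps. Each change therefore depends on the other in these four compounds, so one example was a poor guide to the next core, but the whole difference rests on compound 2, and the data do not show why it stands apart.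

As far as these compounds go, it remains open whether a ring with chloro or methoxy in place of bromo would follow the bromo pair or the methyl pair. Also open, from the compounds shown here alone, is whether a saturated propyl chain or a longer butyl chain in place of allyl would leave these numbers level or shift them.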